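This account rests on a few compounds, and the source may have more. Where it says the series, first, only, none or still open, it means among the compounds named here.

Three compounds share one core. Compound 1 `c1cnc(-c2ccccc2OCC2=NCCN2)nc1` carries a pyrimidin-2-yl group, compound 2 `c1coc(-c2ccccc2OCC2=NCCN2)c1` a furan-2-yl group, and compound 3 `c1csc(-c2ccccc2OCC2=NCCN2)c1` a thiophen-2-yl group. In a functional assay for activation of Alpha-1D adrenergic receptor (Homo sapiens), read by calcium flux (on this read-out lower numbers stand for an effect already at smaller amounts and higher numbers for an effect only at larger amounts of compound), compound 1 gives only a limit of the assay, < 100000 nM. In this assay compound 2 also gives only a limit of the assay, < 100000 nM. The step that the two limits leave unreadable from compound 1 to compound 2 therefore cannot be sized, since both values sit at the limit of < 100000 nM in this assay, at which 2 of the 2 values shown sit. Compound 2 thus stands at a limit and has no number of its own against which a change could be read. The change to compound 3 is thiophen-2-yl in place of furan-2-yl on an aromatic carbon. No measured step bears on it, because the single step shown, a step that the two limits leave unreadable from compound 1 to compound 2, is unreadable between two limits. Compound 3 is expected to remain active in this assay, with an estimated 2000 nM and a range of 100 nM to 50000 nM. The expected step that the limit leaves unreadable from compound 2 to compound 3 is a guess measured from a limit rather than a number.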

Compound 3, half-maximal effective concentration: 15.9 nM
The estimate for compound 3 lay 130-fold (2.10 log units) above the measured number, and the stated range ends above it.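

No step to compound 3 can be read from compound 1 or compound 2, since both of those compounds give only a limit of the assay: the limit of < 100000 nM in this assay, at which 2 of the 3 values shown sit.

The compounds shown leave open how large the change to thiophen-2-yl from furan-2-yl or from pyrimidin-2-yl is.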